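The source may hold more compounds than are shown below. What is called first, only, known or untested is meant among the compounds shown, and "the series" means these compounds.

Working notes on the series. In an ADME assay on S9 fraction from liver (Mus musculus, strain CD-1) for metabolic stability, read by LC-MS, using NADPH, with stated times of 5 min and 60 min, tested at 5 uM (a higher number here means that more of the compound is left, a lower number that less of the compound is left), compound 1 (`COc1ccc(COc2ccc(C3CN(C(=O)c4cc(OCCO)ccn4)C3)cc2OC)cc1`) gives 48%. Compound 2 (`COc1cc(C2CN(C(=O)c3cc(OC[C@@H](O)CO)ccn3)C2)ccc1OCc1ccc(C2CC2)cc1`) gives 68%, the higher of the two numbers, and the gap between them lies beyond the usual scatter. These two compounds differ in more than one place, so the gap cannot be tied to any single change.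

Compound 3 (`COc1cc(C2CN(C(=O)c3cc(OCCCC(C)(C)C(=O)O)ccn3)C2)ccc1OCc1ccc(C2CC2)cc1`) follows from compound 2 by one exchange: 3-carboxy-3-methylbutyl in place of 1,2-dihydroxyethyl on a saturated chain carbon bound to an oxygen on an aromatic ring, (3-carboxy-3-methylbutyl in place of 1,2-dihydroxyethyl on a saturated chain carbon bound to an oxygen on an aromatic ring). The rest of the structure stays as it is. Within the data shown here, no measured pair isolates this exchange, so the data give no direct guide to its size or direction in this assay. A small upward move that stays within the scatter is expected, starting from the 68% of compound 2. The estimated step is a number 4 percentage points higher from compound 2 to compound 3 (within the scatter). For compound 3 the expected value is 72%, with an estimated range of 52% to 88%.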

Compound 3, percent of the compound remaining: 76%
Estimate against measurement, compound 3: 4 percentage points below, within the range that was stated.
By their numbers in this assay, from the lowest: compound 1; then compounds 2 and 3 (each within the scatter of the next).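

In this assay, among these compounds, 3-carboxy-3-methylbutyl in place of 1,2-dihydroxyethyl on a saturated chain carbon bound to an oxygen on an aromatic ring gives a number 8 percentage points higher from compound 2 to compound 3 (within the scatter), the only step that can be read at a single place. This place therefore accepts a substantial exchange without a move beyond the scatter: 8 heavy atoms enter where 4 leave, the 2 hydrogen-bond donors of the leaving group give way to 1 in the entering group, and the defined stereocentre is gone. Nothing available explains why the read-out holds across this exchange.

The compounds shown leave open whether an amine at this place, or an unbranched carboxylic acid chain without the two methyl groups of 3-carboxy-3-methylbutyl, would stay within the scatter of compound 3 in this assay. They also leave open how much of the gap between compound 1 and compound 2 belongs to the group on the saturated chain carbon and how much to the other place in which these two compounds differ.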